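Chloro Addition on Two Fused Cores: Cytotoxicity Expectation

A few compounds are considered here, and "the series" means these few. Any claim that something is new, unique, unknown or untested is made for them only; others in the source may bear on it.

Three compounds have been measured in an ADME assay on HeLa cells (Homo sapiens) for cytotoxicity, read by MTT assay, with a stated time of 72 h; a lower number here means that less compound is tolerated, a higher number that more compound is tolerated:
Compound 1, `Clc1ccc(/C=N/c2sc3c(c2-c2nc4ccccc4s2)CCC3)cc1`, gives 380 ug/mL.
Compound 2, `Clc1ccc(/C=N/c2sc3c(c2-c2nc4ccccc4s2)CCC3)c(Cl)c1`, gives 345 ug/mL.
Compound 3, `Clc1ccc(/C=N/c2sc3c(c2-c2nc4ccccc4s2)CCCC3)cc1`, gives 431 ug/mL.

All three numbers lie within the usual scatter of one another, so none of them can be set apart from the others on this read-out. Compound 2 differs from compound 1 by chloro in place of hydrogen on an aromatic carbon. The size of that step is a 1.1-fold lower number from compound 1 to compound 2 (0.04 log units; within the scatter). Compound 3 and compound 1 carry different cores; the difference between the two cores is not broken down here.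

Compound 4, `Clc1ccc(/C=N/c2sc3c(c2-c2nc4ccccc4s2)CCCC3)c(Cl)c1`, has not yet been measured in this assay. It differs from compound 3 by chloro in place of hydrogen on an aromatic carbon, the same change that turns compound 1 into compound 2, at a place described in the same words. The account therefore expects compound 4 to sit close to compound 3, with an estimated step of a 1.1-fold lower number from compound 3 to compound 4 (0.03 log units; within the scatter), because a 1.1-fold lower number from compound 1 to compound 2 (0.04 log units; within the scatter) stayed within the scatter. Compound 4 is expected to give about 400 ug/mL in this assay, with a likely range from 280 ug/mL to 570 ug/mL.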

Compound 4, half-maximal cytotoxic concentration: 542 ug/mL
Estimate against measurement, compound 4: 1.4-fold (0.13 log units) below; low and high end bracket the measured number.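

In this assay, chloro in place of hydrogen on the aromatic carbon gives a 1.3-fold higher number from compound 3 to compound 4 (0.10 log units; within the scatter). Set beside the same change on the other core, the two steps cannot be told apart: the same change on two cores in this assay, a 1.1-fold lower number (0.04 log units; within the scatter) from compound 1 to compound 2 and a 1.3-fold higher number (0.10 log units; within the scatter) from compound 3 to compound 4, 1.4-fold (0.14 log units) apart, within the scatter of two such steps

The change from 4-chlorophenyl to 2,4-dichlorophenyl therefore carries from the core of compound 1 to the core of compound 3 without any difference this read-out can resolve, but that agreement is one of two small steps, neither of which can be separated from the scatter, and it shows neither that the added chloro has any effect on the tolerated concentration nor that the change would behave alike on any further core.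

The compounds shown leave open whether a group other than chloro at this place, such as a methoxy group, a nitro group, an amine or a carboxylic acid, would give a step that stands clear of the scatter, and whether such a step would then carry between the two cores. They also leave open how the chloro change behaves in any cell type other than the one used here.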